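This account rests on a few compounds, and the source may have more. Where it says the series, first, only, none or still open, it means among the compounds named here.

Working notes on the series, read out in a functional assay on BXPC-3 cells (Homo sapiens) for antiproliferative activity, read by MTT assay, with a stated time of 24 h; a lower number here means a stronger inhibitor, a higher number a weaker inhibitor.

Of the compounds shown here, two carry numbers so far. Compound 1 `CCn1c(C(=O)NCCO)ccc1C(CC)(CC)c1ccc(OCS(=O)(=O)c2ccccc2)c(C)c1` gives 19900 nM in this assay. Compound 2 `CCn1c(C(=O)NCCCO)ccc1C(CC)(CC)c1ccc(OCS(=O)(=O)c2ccccc2)c(C)c1` gives 26600 nM in this assay. Between them lies a single change, hydroxymethyl in place of hydroxy on a saturated chain carbon, two bonds along the chain from an amide-type nitrogen, and the step of a 1.3-fold higher number from compound 1 to compound 2 (0.13 log units; within the scatter) stays within the scatter. Within the data shown here, compound 2 thus stands at the highest of the two numbers, with compound 1 as its only neighbour and within the scatter of it.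

Compound 3 `CCn1c(C(=O)N[C@@H](CC(=O)O)C(=O)O)ccc1C(CC)(CC)c1ccc(OCS(=O)(=O)c2ccccc2)c(C)c1` is the next compound in the series, not yet measured. Against compound 2 the change is 1,2-dicarboxyethyl in place of 3-hydroxypropyl on an amide-type nitrogen. Among the measured compounds shown here, the one measured step, a 1.3-fold higher number from compound 1 to compound 2 (0.13 log units; within the scatter), touches the same amide-type nitrogen but lengthens the chain by one carbon only; it carries no information on a change of this size. For the measured compounds named here, no measured step bears directly on compound 3, so the expectation rests on compound 2 alone. The estimated step of a 1.3-fold higher number from compound 2 to compound 3 (0.12 log units; within the scatter) is expected to stay near or somewhat beyond the scatter towards a higher number, with wide uncertainty. Compound 3 is expected at 35000 nM in this assay, between 10000 nM and 120000 nM.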

Compound 3, half-maximal inhibitory concentration: > 50000 nM
Compound 3: no number, only a limit (the forecaster's own chance of this, stated with the estimate: 30%); middle value at least 1.4-fold (0.15 log units) from the limit.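

For compound 3, this assay gives a limit and not a number: the limit of > 50000 nM in this assay, at which 1 of the 3 values shown sits.

Putting 1,2-dicarboxyethyl on this amide-type nitrogen in place of 3-hydroxypropyl gives an at least 1.8-fold higher number from compound 2 to compound 3 (0.27 log units; that floor lies within the scatter), so this comparison alone does not separate the two compounds, while putting it there in place of 2-hydroxyethyl gives an at least 2.5-fold higher number from compound 1 to compound 3 (0.40 log units; beyond the scatter). Unlike the one-carbon lengthening of the chain, a 1.3-fold higher number from compound 1 to compound 2 (0.13 log units; within the scatter), this exchange is the first change at the position to move the number beyond the scatter, towards weaker inhibition, and its full size remains unknown.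

From the compounds shown here alone, whether a single carboxylic acid, an amine or a longer hydroxyalkyl chain on this amide-type nitrogen would stay with the two hydroxy compounds or move with compound 3 remains open. Also open, going by these compounds, is whether the step belongs to the two carboxylic acids together, to one of them, or to the defined stereocentre that enters with 1,2-dicarboxyethyl.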